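The compounds below may be only part of what the source reports. "The series", "measured", "known", "first", "only" and "open" are said of these compounds alone.

Among the compounds with values here, in a physicochemical assay, with a stated time of 6 min (on this read-out lower numbers stand for stronger inhibition and higher numbers for weaker inhibition), compound 1 (`O=C(Nc1ccc(F)cc1)Nc1nc(-c2cc3ccccc3o2)cs1`) gives 1130 nM, the only true number so far. Compound 2 (`Cc1ccc(NC(=O)Nc2nc(-c3cc4cc(Br)ccc4o3)cs2)cc1`) reads > 200000 nM, which is a limit and not a number. Compound 3 (`COc1cccc(NC(=O)Nc2nc(-c3cc4cc(Br)ccc4o3)cs2)c1`) reads > 200000 nM, also a limit. Within the data shown here, the one measured step, a step that the two limits leave unreadable from compound 2 to compound 3, therefore gives no size to carry forward. Compound 4 (`O=C(Nc1cccc(F)c1)Nc1nc(-c2cc3ccccc3o2)cs1`) differs from compound 1 as follows: 3-fluorophenyl in place of 4-fluorophenyl on an amide-type nitrogen, with 3-fluorophenyl in place of 4-fluorophenyl on an amide-type nitrogen. Among the measured compounds shown here, no measured step covers this change, so no shift beyond the scatter is expected in this assay, though with low confidence and a wide range. The expected change is a 1.2-fold higher number from compound 1 to compound 4 (0.06 log units; within the scatter). Compound 4 is estimated at 1300 nM, with an expected range of 300 nM to 6000 nM.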

Compound 4, half-maximal inhibitory concentration: 4520 nM
Estimate against measurement, compound 4: 3.5-fold (0.54 log units) below; the measured number falls inside the stated range.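

In this assay, 3-fluorophenyl in place of 4-fluorophenyl on an amide-type nitrogen gives a 4.0-fold higher number from compound 1 to compound 4 (0.60 log units; beyond the scatter). Within the data shown here, this is the only readable step, and it shows that the read-out depends on where the fluorine stands on this phenyl ring, with the atoms unchanged. The earlier step cannot be read, because compound 2 and compound 3 both carry a limit and not a number: the limit of > 200000 nM in this assay, at which 2 of the 4 values shown sit.

On these data alone, how an unsubstituted phenyl or a carboxylic acid on this ring would read stays open. Also open, as far as these compounds go, is whether the fluorine step holds on the bromine-bearing core of compound 2 and compound 3.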